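Fluoro for methylsulfonyl on the N-aryl ring of compound 2

This account rests on a few compounds, and the source may have more. Where it says the series, first, only, none or still open, it means among the compounds named here.

Measured in a functional assay on Hep 3B2 cells (Homo sapiens) for inhibition, read by sulforhodamine B assay, with a stated time of 72 h, tested at 10 uM; a lower number here means less inhibition, a higher number more inhibition at the concentration tested (going by the name of the read-out):
compound 1 `CC(C)[C@H](Nc1ncnc2[nH]cnc12)c1nn(-c2cccnc2)c2cc(F)ccc12` gives 4%
compound 2 `C[C@H](Nc1ncnc2[nH]cnc12)c1nn(-c2cccc(S(C)(=O)=O)c2)c2cc(F)ccc12` gives 11%
compound 3 `C[C@H](Nc1nc(N)nc(N)c1C#N)c1nn(-c2cccc(S(C)(=O)=O)c2)c2cc(F)ccc12` gives 36%

Compound 2 sits among the lower numbers in this assay: its value and that of compound 1 lie within the usual scatter of each other, while compound 3 stands higher by a number 25 percentage points higher from compound 2 to compound 3 (beyond the scatter), a modest step that arises from exchanging the group on the amine nitrogen, not from anything on the N-aryl ring.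

Compound 4 `C[C@H](Nc1ncnc2[nH]cnc12)c1nn(-c2cccc(F)c2)c2cc(F)ccc12` differs from compound 2 by fluoro in place of methylsulfonyl on an aromatic carbon, that is 3-(methylsulfonyl)phenyl to 3-fluorophenyl. Within the data shown here, no measured pair in this set isolates a change on that ring; compound 1 differs from compound 2 in two places at once, so only its two values can be compared, and they lie within the scatter. Among the measured compounds shown here, there is therefore no measured step that bears on this change, and no step beyond the scatter in this assay is expected from compound 2 to compound 4, the estimated step being a number 2 percentage points lower from compound 2 to compound 4 (within the scatter).

Compound 4 is expected to give about 9% in this assay, within 0% to 24%.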

Compound 4, a percentage reported as inhibition, at one concentration (the size of the read-out at that concentration, not a potency): 28%
Estimate against measurement, compound 4: 19 percentage points below; the measured number lies above the stated range.
By their numbers in this assay, from the lowest: compounds 1 and 2 (each within the scatter of the next); then compounds 4 and 3 (each within the scatter of the next).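

In this assay, the N-aryl ring proves to be a place where a single change moves the read-out (a number 17 percentage points higher from compound 2 to compound 4 (beyond the scatter)), with fluoro in place of methylsulfonyl on an aromatic carbon. Until now, the only step shown from compound 2 came from exchanging the group on the amine nitrogen (a number 25 percentage points higher from compound 2 to compound 3 (beyond the scatter)), so two separate places on compound 2 now respond to a change. The data shown offer no measured explanation for the step from methylsulfonyl to fluoro.

Still open, going by these compounds, is whether the step reflects the loss of methylsulfonyl or the arrival of fluoro, a question that a plain hydrogen, chloro or methoxy group on the same carbon could help to separate. Also open, on these data alone, is whether the fluoro change and the group on the amine nitrogen of compound 3 would add up in one compound.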